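The source may hold more compounds than are shown below. What is called first, only, known or untested is meant among the compounds shown, and "the series" means these compounds.

Values in a functional assay on HL-60 cells (Homo sapiens) for cytotoxicity, read by MTT assay, with a stated time of 96 h (on this read-out lower numbers stand for stronger inhibition and higher numbers for weaker inhibition), for the measured compounds:

Compound 1 (`CC[C@H](N)C(=O)N[C@@H]1C(=O)N2[C@@H](CC[C@@H]1CNC(=O)NCc1ccccc1)CC[C@H]2C(=O)NC(c1ccccc1)c1ccccc1`): 51000 nM
Compound 2 (`CC[C@H](N)C(=O)N[C@@H]1C(=O)N2[C@@H](CC[C@@H]1CCO)CC[C@H]2C(=O)NC(c1ccccc1)c1ccccc1`): > 100000 nM (a limit, not a number)

Compound 2 stands at > 100000 nM as a limit of the assay and not as a number. Compound 3 (`CC[C@H](N)C(=O)N[C@@H]1C(=O)N2[C@@H](CC[C@@H]1CCNC(=O)c1ccccc1)CC[C@H]2C(=O)NC(c1ccccc1)c1ccccc1`) has no value yet. The change from compound 2 is benzamido in place of hydroxy on a saturated chain carbon, two bonds along the chain from a saturated ring carbon and puts benzamido in place of hydroxy on a saturated chain carbon, two bonds along the chain from a saturated ring carbon. Among the compounds with values here, one measured step bears on this change: an at least 1.9-fold higher number from compound 1 to compound 2 (0.29 log units; that floor lies within the scatter) and it also alters the end of the side chain. As far as these compounds go, the true size of that step stays open because of the limit of > 100000 nM in this assay, at which 1 of the 2 values shown sits, and no firmer guide is available. Since compound 1 at 51000 nM also carries a six-membered aromatic ring in its side chain, a modest move toward a lower number in this assay is expected for compound 3, possibly no larger than the scatter. The expected change is an at least 1.6-fold lower number from compound 2 to compound 3 (0.22 log units; that floor lies within the scatter) and it may not clear the scatter. In this assay the estimated value for compound 3 is 60000 nM (expected range 25000 nM to 100000 nM).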

Compound 3, half-maximal inhibitory concentration: 50700 nM
For compound 3 the middle estimate is 1.2-fold (0.07 log units) above the measured one, and the stated range covers the measured number.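

In this assay compound 2 stands at > 100000 nM, a limit and not a number. Within the data shown here, with benzamido in place of hydroxy on a saturated chain carbon, two bonds along the chain from a saturated ring carbon, the side chain now gives a real number, and the result is an at least 1.9-fold lower number from compound 2 to compound 3 (0.29 log units; that floor lies within the scatter), but the floor of that step does not clear the scatter and its true size stays open: the limit of > 100000 nM in this assay, at which 1 of the 3 values shown sits. What the earlier compounds did not show is that two differently linked side-chain ends, each with a six-membered aromatic ring, cannot be told apart in this assay: benzamidomethyl in place of (benzylcarbamoyl)amino gives a 1.0-fold lower number from compound 1 to compound 3 (0.00 log units; within the scatter).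

The compounds shown leave open whether the aromatic ring or the amide link goes with the number, and a 2-acetamidoethyl or 2-aminoethyl group in place of 2-benzamidoethyl would separate the two. They also leave open whether any end at this position, such as a carboxylic acid or a benzamido group on a longer chain, could reach a much lower number in this assay.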